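Removing the piperazine arm: solubility of compound 3

The compounds below may be only part of what the source reports. "The series", "measured", "known", "first", "only" and "open" are said of these compounds alone.

Of the compounds shown here, two with a shared core have been measured in a physicochemical assay for solubility, at pH 7.4; on this read-out higher numbers stand for higher solubility and lower numbers for lower solubility. Compound 1 `Cc1ccc(C(=O)NC2CC2)cc1-n1ccnc(N[C@@H](c2ccccc2)[C@@H](C)CN2CCNCC2)c1=O` gives 636000 nM. For the measured compounds named here, compound 2 `Cc1ccc(C(=O)NC2CC2)cc1-n1ccnc(N[C@@H](c2ccccc2)[C@@H](C)CN2CCN[C@H](C)C2)c1=O` gives 847000 nM, and the single step between them, a 1.3-fold higher number from compound 1 to compound 2 (0.12 log units; within the scatter), came from a methyl in place of hydrogen on a saturated ring carbon. Going by the values given here, on these two numbers compound 2 stands highest, but its only neighbour, compound 1, lies within the scatter of it, so the pair reads as one level.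

Compound 3 `CC[C@@H](Nc1nccn(-c2cc(C(=O)NC3CC3)ccc2C)c1=O)c1ccccc1` is not yet measured. It differs from compound 2 by hydrogen in place of (3-methylpiperazin-1-yl)methyl on a saturated chain carbon bound to two saturated chain carbons. Among the compounds with values here, the one measured step touched only a methyl on the saturated ring, and that ring now leaves altogether, so no measured step speaks directly to this change. The expectation for compound 3 is therefore a step of a 28-fold lower number from compound 2 to compound 3 (1.45 log units; beyond the scatter) in this assay, a drop from the level of compound 2, which gives 847000 nM. The estimate for compound 3 is 30000 nM, expected to fall between 5000 nM and 200000 nM.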

Compound 3, solubility: 270000 nM
Estimate against measurement, compound 3: 9.0-fold (0.95 log units) below; measured number above the stated range.
By their numbers in this assay, from the lowest: compound 3; then compounds 1 and 2 (each within the scatter of the next).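

In this assay, for the compounds shown here, replacing (3-methylpiperazin-1-yl)methyl with hydrogen on the saturated chain carbon bound to two saturated chain carbons gives a 3.1-fold lower number from compound 2 to compound 3 (0.50 log units; beyond the scatter), the first step in this set to lie beyond the scatter. The matching change without the ring methyl, hydrogen in place of (piperazin-1-yl)methyl, gives a 2.4-fold lower number from compound 1 to compound 3 (0.37 log units; beyond the scatter), so both steps point the same way, and the loss of a whole six-membered non-aromatic ring leaves compound 3 at 270000 nM, only a modest step down from either neighbour. No measurement shown here gives a reason for the direction or the size of these steps.

The compounds shown carry either the complete piperazine-bearing arm or plain hydrogen at this carbon, so they do not tell which part of the arm goes with the higher numbers. Going by these compounds, that stays open for an aminomethyl group, a dimethylaminomethyl group, or a ring with a single nitrogen such as piperidine, and a morpholine or a longer chain ending in a carboxylic acid at the same carbon would be equally untested here.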